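A few compounds are considered here, and "the series" means these few. Any claim that something is new, unique, unknown or untested is made for them only; others in the source may bear on it.

Three compounds share one core, a hydroxamic acid on a benzene ring joined through an amine to a triazole carrying two aryl groups. Compound 1 `O=C(NO)c1ccc(NCc2nc(-c3ccccc3)nn2-c2ccccc2Cl)cc1` gives 9630 nM in a functional assay on MGC-803 cells (Homo sapiens) for antiproliferative activity, read by MTT assay, with a stated time of 72 h; a higher number here means a weaker inhibitor, a lower number a stronger inhibitor. Compound 2 `Cc1ccccc1-n1nc(-c2ccccc2)nc1CNc1ccc(C(=O)NO)cc1` gives 12300 nM in this assay, and the step of a 1.3-fold higher number from compound 1 to compound 2 (0.11 log units; within the scatter) shows that swapping the group on the ring attached to the triazole nitrogen leaves the number essentially where it was. Compound 3 `O=C(NO)c1ccc(NCc2nc(-c3ccc(F)cc3)nn2-c2ccccc2)cc1` gives 8960 nM in this assay; among the three numbers it is the lowest, but its gap to compound 1 and its gap to compound 2 both fall within the scatter, so no ordering among them can be claimed.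

Compound 4 `O=C(NO)c1ccc(NCc2nc(-c3ccc(Cl)cc3)nn2-c2ccccc2)cc1` differs from compound 3 by chloro in place of fluoro on an aromatic carbon. For the measured compounds named here, no measured step exchanges these two halogens, and the only step available, between compound 1 and compound 2, concerns a different ring and is itself within the scatter. The change is small in size and adds no donors or acceptors, so the author expects no step beyond the scatter. The step from compound 3 to compound 4 is expected to be a 1.1-fold lower number from compound 3 to compound 4 (0.05 log units; within the scatter). For compound 4 the estimate in this assay is 8000 nM, with a range from 4000 nM to 16000 nM.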

Compound 4, half-maximal inhibitory concentration: 5970 nM
Beside the measured number, compound 4's estimate is 1.3-fold (0.13 log units) above it; the range from low to high includes it.
By their numbers in this assay, from the lowest: compounds 4, 3, 1 and 2 (each within the scatter of the next, the first and the last beyond it).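

For the compounds shown here, until now no measured step exchanged the halogen on the 4-fluorophenyl group, and in this assay the step of a 1.5-fold lower number from compound 3 to compound 4 (0.18 log units; within the scatter) supplies the first reading for this position. Chloro in place of fluoro, on an aromatic carbon para to a large group and with no hydrogen-bond donor or acceptor entering or leaving, stays inside the scatter, as does the step of a 1.3-fold higher number from compound 1 to compound 2 (0.11 log units; within the scatter) on the other ring, so neither single change shown separates its two compounds. No accompanying measurement bears on this result.

The compounds shown leave open whether any group at this position can give a step beyond the scatter, a question that a methoxy group, a trifluoromethyl group, an amine or a carboxylic acid in place of the halogen would put more sharply than one halogen exchanged for another. They also leave open how the number responds to a change elsewhere on the shared core, for instance a carboxylic acid in place of the hydroxamic acid or a longer chain in the link to the amine.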